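One Stereocentre Turned Around in Compound 3

The source may report more compounds than this note shows. Statements on the series, on what has been measured and on what is new or still open speak of the compounds shown alone.

Of the compounds shown here, three have been measured in a functional assay on U-251 cells (Homo sapiens) for inhibition; on this read-out higher numbers stand for weaker inhibition of growth and lower numbers for stronger inhibition of growth. Compound 1 `C=C1CCCC(C)(C)C1(O)CC/C(C)=C/CC[C@]1(C)CC[C@@H]([C@@H](C)C(=O)OC)OO1` and compound 2 `C=C1CCCC(C)(C)C1CC[C@]1(C)CC[C@H]([C@@H](C)C(=O)OC)OO1` resemble compound 3 only in part, so for them just their own numbers can be given. In this assay compound 1 gives > 17500 nM, which is a limit of the assay and not a number. In this assay compound 2 gives 2910 nM. Compound 3 `CC1=C(CC/C(C)=C/CC[C@@]2(C)CC[C@@H]([C@H](C)C(=O)O)OO2)C(C)(C)CCC1` gives > 100000 nM in this assay; this too is a limit of the assay rather than a number, so compound 3 sits at the edge of what this assay can report (the limit of > 100000 nM in this assay, at which 1 of the 3 values shown sits). Compound 4 `CC1=C(CC/C(C)=C/CC[C@@]2(C)CC[C@H]([C@H](C)C(=O)O)OO2)C(C)(C)CCC1` is the compound not yet measured: the two compounds have the same atoms and bonds and differ only in configuration as drawn: 1 of 4 stereo elements differ; a stereocentre at a saturated ring carbon is drawn S in compound 3 and R in compound 4. Among the measured compounds shown here, no step between two measured compounds shows what such a change does here. Since compound 3 already stands at a limit, compound 4 is expected to come out near that limit as well, and the step that the limit leaves unreadable from compound 3 to compound 4 is expected to be none beyond the scatter. The estimate for compound 4 is 120000 nM, with a range from 30000 nM to 500000 nM.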

Compound 4, concentration for 50% growth inhibition: > 5000 nM
Compound 4 was reported as a limit; the forecaster's own chance of this, stated with the estimate: 75%; the middle value is on the limit's open side.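

Among the compounds shown here, compound 3 and compound 4 differ only at one stereocentre on a saturated ring carbon, but both results are limits of the assay and not numbers, so no step between them can be read. Going by these compounds, what turning this stereocentre around does in this assay stays open.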